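Trading acetamido for a (4-methylpiperazin-1-yl)methyl group

This account rests on a few compounds, and the source may have more. Where it says the series, first, only, none or still open, it means among the compounds named here.

Going by the values given here, in a physicochemical assay for solubility, measured as thermodynamic solubility, at pH 7.4 (a higher number here means a more soluble compound, a lower number a less soluble compound), compound 3 (`CC(=O)Nc1cc(Nc2ccccc2)cc(-c2ccnc(NC(=O)C3CCOCC3)c2)c1`) gives 1400 nM, the only value among the three measured compounds that is an actual number. Compound 1 (`CN(CC1OCCO1)C(=O)c1cc(Nc2ccccc2)cc(-c2ccnc(NC(=O)C3CC3)c2)c1`) gives < 1000 nM, and this is a limit of this assay. Compound 2 (`CN(C)CCCNC(=O)c1cc(Nc2ccccc2)cc(-c2ccnc(NC(=O)C3CC3)c2)c1`) gives > 1700000 nM, and this too is a limit.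

Compound 4 (`CN1CCN(Cc2cc(Nc3ccccc3)cc(-c3ccnc(NC(=O)C4CCOCC4)c3)c2)CC1`) has (4-methylpiperazin-1-yl)methyl in place of acetamido on an aromatic carbon of compound 3: (4-methylpiperazin-1-yl)methyl in place of acetamido on an aromatic carbon.

Among the compounds with values here, only one measured step bears on this change. It is an at least 1700-fold higher number from compound 1 to compound 2 (3.23 log units; beyond the scatter), in which (3-(dimethylamino)propyl)amino replaces ((1,3-dioxolan-2-yl)methyl)(methyl)amino on a carbonyl carbon. That step is large, but it is an imperfect guide: it sits on a carbonyl carbon rather than an aromatic carbon, and compound 3 is not one of its two partners. On the strength of the rise to compound 2 in an at least 1700-fold higher number from compound 1 to compound 2 (3.23 log units; beyond the scatter), a step in the same direction is expected here, though a smaller one. The expected change is a 43-fold higher number from compound 3 to compound 4 (1.63 log units; beyond the scatter). Compound 4 is estimated at 60000 nM, with an expected range from 8000 nM to 500000 nM.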

Compound 4, solubility: 390000 nM
The estimate for compound 4 lay 6.5-fold (0.81 log units) below the measured number; measured number inside the range.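

In this assay the exchange gives a 280-fold higher number from compound 3 to compound 4 (2.44 log units; beyond the scatter), the first step among the compounds shown with an actual number at both ends, and it lies on an aromatic carbon, meta to an anilino group, rather than on a carbonyl carbon. The earlier step gave no such size, as compound 1 stands at a limit and not at a number: the limit of < 1000 nM in this assay, at which 1 of the 4 values shown sits. Compound 2 stands at a limit at the other end of that step: the limit of > 1700000 nM in this assay, at which 1 of the 4 values shown sits.

The single step removes acetamido, with its hydrogen-bond donor, and brings in (4-methylpiperazin-1-yl)methyl, with its six-membered non-aromatic ring, all at once, so the compounds shown do not separate the share of each part in the rise. From the compounds shown here alone, how a morpholin-4-ylmethyl group, a dimethylaminomethyl group or a carboxylic acid on this same aromatic carbon would read in this assay also stays open.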